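Carboxy on the Piperidine of a Leukotriene Hydrolase Inhibitor

The source may report more compounds than this note shows. Statements on the series, on what has been measured and on what is new or still open speak of the compounds shown alone.

Three compounds built on one shared core have been examined in an assay on isolated protein (blood, strain CD1) for inhibition of leukotriene A-4 hydrolase (Mus musculus), read by immunoassay, with stated times of 15 min and 30 min; on this read-out lower numbers stand for stronger inhibition and higher numbers for weaker inhibition. Compound 1 `c1ccc2sc(Oc3ccc4oc(CN5CCCCC5)cc4c3)nc2c1` and compound 2 `c1ccc2sc(Oc3ccc4cc(CN5CCCCC5)oc4c3)nc2c1` carry the piperidine on different positions of the bicyclic portion, and for neither is a result reported: in this assay compound 1 gives "not determined" (no result reported) and compound 2 gives "not determined" (no result reported). Among the compounds with values here, compound 3 `c1cnc2nc(Oc3ccc4c(CN5CCCCC5)coc4c3)sc2c1` is therefore the only compound with a number: in this assay compound 3 gives 21 nM, and with no second value there is no step between measured compounds to compare it with.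

The unmeasured compound 4 `O=C(O)C1CCN(Cc2coc3cc(Oc4nc5ncccc5s4)ccc23)CC1` keeps everything of compound 3 except for one change, (carboxy in place of hydrogen on a saturated ring carbon). The piperidine ring gains a carboxy group, that is, piperidin-1-yl becomes 4-carboxypiperidin-1-yl, while the rest of the molecule is unchanged.

Within the data shown here, nothing in the data shows what such a change does to this assay, so the expectation for compound 4 rests on the single value of compound 3 alone. The step from compound 3 to compound 4 is expected to be small, a 1.4-fold higher number from compound 3 to compound 4 (0.15 log units; within the scatter), and probably not beyond the usual scatter in either direction. Compound 4 is thus expected to give about 30 nM, with a range from 8 nM to 120 nM.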

Compound 4, half-maximal inhibitory concentration: 280 nM
Beside the measured number, compound 4's estimate is 9.3-fold (0.97 log units) below it; measured number above the stated range.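

In this assay, within the data shown here, carboxy in place of hydrogen on a saturated ring carbon, three ring bonds from the ring nitrogen, gives a 13-fold higher number from compound 3 to compound 4 (1.12 log units; beyond the scatter), the first measured step and one beyond the scatter. This ring carbon of the piperidine is therefore not indifferent to substitution, at least for this change, although the inhibition is weakened rather than lost: compound 4 still gives a number, 280 nM. The data shown offer no measurement that could account for the size of this step.

The compounds shown leave open whether a methyl ester, a primary amide or a hydroxymethyl group on the same ring carbon would cost as much as the carboxy, and whether a carboxylic acid carried on a longer chain would behave differently from one attached directly to the ring. Steps involving compound 1 and compound 2 cannot be read, so the effect of attaching the piperidine at other places on the bicyclic portion also remains open.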